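The source may report more compounds than this note shows. Statements on the series, on what has been measured and on what is new or still open speak of the compounds shown alone.

Measured so far in an assay for inhibition of Fatty-acid amide hydrolase 1 (Rattus norvegicus); a lower number here means a stronger inhibitor, a higher number a weaker inhibitor:
- compound 1, `NC(=O)c1cnc(C(=O)CCc2ccc(Oc3ccccc3)cc2)o1`: 6.6 nM
- compound 2, `COC(=O)c1ccc(-c2cnc(C(=O)CCc3ccc(-c4ccccc4)cc3)o2)nc1`: 2.2 nM
- compound 3, `CN(C)C(=O)c1cnc(C(=O)CCc2ccc(COc3ccccc3)cc2)o1`: 6.7 nM

Compound 2 gives the lowest number of the three. Compound 1 and compound 3 both stand above it by a margin beyond the usual scatter, and the two of them are separated from each other by a gap within the scatter, so no order between compound 1 and compound 3 is claimed.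

Compound 4, `COC(=O)c1ccc(-c2cnc(C(=O)CCc3ccc(-c4ccccc4)cc3)o2)cn1`, is not yet measured in this assay. It has the same atoms as compound 2 joined differently: 6-(methoxycarbonyl)pyridin-3-yl in place of 5-(methoxycarbonyl)pyridin-2-yl on an aromatic carbon. The group that leaves and the group that enters match in size, ring count and hetero atom count; the attachment point on the pyridine ring is all that moves. Among the compounds with values here, no measured pair tests this kind of change, so there is no step to draw on, and the expectation rests on the value of compound 2 alone.

The step expected from compound 2 to compound 4, a 1.4-fold higher number from compound 2 to compound 4 (0.13 log units; within the scatter), is small, in either direction, and not clearly beyond the scatter. Compound 4 is therefore estimated at 3 nM, within a range from 1 nM to 9 nM.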

Compound 4, inhibition constant: 0.6 nM
Estimate against measurement, compound 4: 5.0-fold (0.70 log units) above; measured number outside the range, below it.
By their numbers in this assay, from the lowest: compound 4; then compound 2; then compounds 1 and 3 (each within the scatter of the next).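

In this assay, the step of a 3.7-fold lower number from compound 2 to compound 4 (0.56 log units; beyond the scatter) comes with 6-(methoxycarbonyl)pyridin-3-yl in place of 5-(methoxycarbonyl)pyridin-2-yl on the aromatic carbon next to the ring oxygen. Within the data shown here, this is the first one-place comparison, and it shows that this position responds beyond the scatter to an isomeric change alone, since the two groups match in heavy atoms, rings, hydrogen-bond donors and acceptors. No available evidence accounts for this step.

On these data alone, it remains open whether the step persists with a carboxylic acid or a primary amide in place of the methoxycarbonyl group on the pyridine ring. Also open, as far as these compounds go, is how an unsubstituted phenyl ring at this position would compare with either pyridine group.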